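Hydrazone isomers of a coumarin carbohydrazide series

A few compounds are considered here, and "the series" means these few. Any claim that something is new, unique, unknown or untested is made for them only; others in the source may bear on it.

Measured so far in a functional assay on CCRF-CEM cells (Homo sapiens) for antiproliferative activity, read by fluorescence and resazurin assay, with a stated time of 48 h; on this read-out higher numbers stand for weaker inhibition and lower numbers for stronger inhibition:
- compound 1 `CCOc1ccc2nc(Cl)c(/C=N/NC(=O)c3cc4cc(Br)ccc4oc3=O)cc2c1`: 12900 nM
- compound 2 `O=C(N/N=C/c1ccncc1)c1cc2ccccc2oc1=O`: 3110 nM

Compound 2 has the lower of the two numbers in this assay; compound 1 gives the higher one, and the gap between them lies beyond the scatter. Compound 3 `O=C(N/N=C/c1cccnc1)c1cc2ccccc2oc1=O` is the positional isomer of compound 2 that has not yet been measured. The change is pyridin-3-yl in place of pyridin-4-yl on a carbon with a double bond to nitrogen. The two share the same atoms, joined differently, so only the position of the ring nitrogen is moved.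

Among the compounds with values here, no measured pair in this set differs in one place, so no measured step gives a reference for the size of such a change. With the rest of the molecule unchanged, the step from compound 2 to compound 3 is expected to be small in this assay, most likely none beyond the scatter, with no clear direction favoured: a 1.3-fold higher number from compound 2 to compound 3 (0.11 log units; within the scatter).

Compound 3 is therefore estimated at 4000 nM in this assay, with a range from 1500 nM to 12000 nM.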

Compound 3, half-maximal inhibitory concentration: 9900 nM
The estimate for compound 3 lay 2.5-fold (0.39 log units) below the measured number, within the range that was stated.
By their numbers in this assay, from the lowest: compound 2; then compounds 3 and 1 (each within the scatter of the next).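

Within this assay the series now has its first measured step in one place, and moving only the ring nitrogen gives a 3.2-fold higher number from compound 2 to compound 3 (0.50 log units; beyond the scatter) in the direction of weaker inhibition. This position, on a carbon with a double bond to nitrogen, therefore responds to where the ring nitrogen sits, with pyridin-4-yl ahead of pyridin-3-yl, although the heavy-atom, donor and acceptor counts of the two groups are identical. No measurement at hand accounts for this difference.

Still open, as far as these compounds go, is how pyridin-2-yl or a plain phenyl ring would fall relative to these two groups on the same carbon. Also open, from the compounds shown here alone, is whether the step keeps its size and direction when the shared core carries a further group, such as a methoxy or a carboxylic acid.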